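Trifluoromethyl for trifluoromethoxy: expected cytotoxicity of compound 3

The compounds below may be only part of what the source reports. "The series", "measured", "known", "first", "only" and "open" are said of these compounds alone.

Compound 1 `CC(C)(C)c1ccc(-c2nnc(CNC(=O)c3ccc([N+](=O)[O-])o3)o2)cc1` gives 3.63 ug/mL in a toxicity assay on Vero cells (Chlorocebus sabaeus) for cytotoxicity, read by MTT assay, with a stated time of 72 h; on this read-out higher numbers stand for lower toxicity in this test and lower numbers for higher toxicity in this test. Among the compounds with values here, compound 2 `O=C(NCc1nnc(-c2ccc(OC(F)(F)F)cc2)o1)c1ccc([N+](=O)[O-])o1` gives 3.48 ug/mL in this assay and stands alongside compound 1, the only other measured compound, since the step of a 1.0-fold lower number from compound 1 to compound 2 (0.02 log units; within the scatter) lies within the scatter. Compound 3 `O=C(NCc1nnc(-c2ccc(C(F)(F)F)cc2)o1)c1ccc([N+](=O)[O-])o1` differs from compound 2 by trifluoromethyl in place of trifluoromethoxy on an aromatic carbon. Within the data shown here, the one step that bears on this position, from compound 1 to compound 2, was within the scatter, so no change beyond the scatter is expected in this assay. Compound 3 is therefore estimated at 3.5 ug/mL, with a range of 1.8 ug/mL to 7 ug/mL, an expected step of a 1.0-fold higher number from compound 2 to compound 3 (0.00 log units; within the scatter).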

Compound 3, half-maximal cytotoxic concentration: 3.56 ug/mL
Estimate against measurement, compound 3: 1.0-fold (0.01 log units) below; measured number inside the range.
By their numbers in this assay, from the lowest: compounds 2, 3 and 1 (each within the scatter of the next).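

Trifluoromethyl in place of trifluoromethoxy gives a 1.0-fold higher number from compound 2 to compound 3 (0.01 log units; within the scatter) in this assay, so losing the oxygen of that group does not move the read-out beyond the scatter. Trifluoromethyl in place of tert-butyl gives a 1.0-fold lower number from compound 1 to compound 3 (0.01 log units; within the scatter), which adds a second step at this position that stays within the scatter, and all three groups now read alike. No measured evidence bears on why these values sit together. The compounds shown leave open whether an amine, a carboxylic acid or a longer chain at this position would also stay within the scatter.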